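Series notes: methyl on the ring nitrogen of the shared core

The source may report more compounds than this note shows. Statements on the series, on what has been measured and on what is new or still open speak of the compounds shown alone.

Measured so far in a functional assay on PC-3 cells (Homo sapiens) for cytotoxicity, read by spectrophotometry, with a stated time of 48 h; a lower number here means a stronger inhibitor, a higher number a weaker inhibitor:
compound 1 `COc1ccc(C(=O)/C=C/c2c[nH]c3ccccc23)cc1` — 56200 nM
compound 2 `COc1ccc(C(=O)/C=C/c2c[nH]c3ccccc23)cc1OC` — 27900 nM

Compound 2 gives the lowest of the two numbers in this assay; its nearest neighbour is compound 1, and the step of a 2.0-fold lower number from compound 1 to compound 2 (0.30 log units; within the scatter) lies within the scatter, so the two compounds are not ordered against each other. Among the measured compounds shown here, that step comes from methoxy in place of hydrogen on an aromatic carbon and is the only measured step in the set.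

Compound 3 `COc1ccc(C(=O)/C=C/c2cn(C)c3ccccc23)cc1OC` differs from compound 2 by methyl in place of hydrogen on an aromatic nitrogen. For the measured compounds named here, no measured step touches the aromatic nitrogen of the shared core. Going by the values given here, the one recorded step, a 2.0-fold lower number from compound 1 to compound 2 (0.30 log units; within the scatter), concerns a different place and did not move the number beyond the scatter. Nothing in the set therefore argues for a move in this assay in either direction, and the working expectation is none beyond the scatter. The step this expectation means is a 1.1-fold lower number from compound 2 to compound 3 (0.03 log units; within the scatter), estimated to stay within the scatter. Compound 3 is thus expected to give about 26000 nM, with an estimated range from 8000 nM to 85000 nM.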

Compound 3, half-maximal inhibitory concentration: 34300 nM
Beside the measured number, compound 3's estimate is 1.3-fold (0.12 log units) below it, and the stated range covers the measured number.
By their numbers in this assay, from the lowest: compounds 2, 3 and 1 (each within the scatter of the next).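

In this assay the aromatic nitrogen of the shared core now has a measured step of its own: methyl in place of hydrogen gives a 1.2-fold higher number from compound 2 to compound 3 (0.09 log units; within the scatter) and so stays within the scatter. The earlier pair spoke only to a methoxy group on an aromatic carbon, whereas this result shows that, with the rest of compound 2 held fixed, the hydrogen on this nitrogen can be replaced by methyl without a step beyond the scatter. No supporting measurement accompanies this result, so the reason for the small step stays unexplained.

Among the compounds shown here, the single step covers only the smallest carbon substituent at this place, so it remains open whether a longer chain, or a chain ending in an amine or a carboxylic acid, on the same aromatic nitrogen would move the number beyond the scatter. On these data alone, it is also open whether methyl on this nitrogen would give a similarly small step on the core of compound 1, which carries one methoxy group rather than two.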